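This account rests on a few compounds, and the source may have more. Where it says the series, first, only, none or still open, it means among the compounds named here.

Working notes on the series.

Compound 1 `CCOC(=O)c1ccc(-c2nn(CC)c3ccccc23)cc1` and compound 2 `CCOC(=O)c1ccc(-c2nn(C(C)C)c3ccccc23)cc1` share one core; compound 3 `CCNC(=O)c1ccc(-c2nn(Cc3ccccc3)c3ccccc23)cc1` carries a different one. In a functional assay on cells (Platelet, Homo sapiens) for inhibition (a higher number here means a weaker inhibitor, a lower number a stronger inhibitor), compound 1 gives > 10000 nM, a limit of the assay rather than a number. In this assay compound 2 gives > 10000 nM, likewise a limit. In this assay compound 3 gives > 10000 nM, again a limit.

The move from compound 1 to compound 2 is methyl in place of hydrogen on a saturated chain carbon bound to an aromatic nitrogen and a saturated chain carbon. The step it made, a step that the two limits leave unreadable from compound 1 to compound 2, cannot be sized, since both ends sit at the limit of > 10000 nM in this assay, at which 3 of the 3 values shown sit. The difference between the core of compound 1 and the core of compound 3 is not broken down here.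

Compound 4 `CCCNC(=O)c1ccc(-c2nn(Cc3ccccc3)c3ccccc23)cc1` is not yet measured. It arises from compound 3 by methyl in place of hydrogen on a saturated chain carbon, two bonds along the chain from an amide-type nitrogen. This is the same kind of change as that from compound 1 to compound 2, but not the same: there the place was on a saturated chain carbon bound to an aromatic nitrogen and a saturated chain carbon, here it is on a saturated chain carbon, two bonds along the chain from an amide-type nitrogen.

The expected step from compound 3 to compound 4 in this assay is a step that the limit leaves unreadable from compound 3 to compound 4, resting on a step that the two limits leave unreadable from compound 1 to compound 2 and on (the limit of > 10000 nM in this assay, at which 3 of the 3 values shown sit), where every shown value sits. Compound 4 is therefore estimated to give 12000 nM in this assay, with a range from 3000 nM to 40000 nM, most likely reported again only as a limit.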

Compound 4, half-maximal inhibitory concentration: > 10000 nM
Compound 4 gave a limit, no number (the forecaster's own chance of this, stated with the estimate: 85%); the middle value is on the limit's open side.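

In this assay compound 4 gives > 10000 nM, again a limit of the assay. No step can be read between compound 3 and compound 4, as both sit at a limit: the limit of > 10000 nM in this assay, at which 4 of the 4 values shown sit.

The compounds shown leave open whether the core of compound 1 or the core of compound 3 can give a measured number rather than a limit in this assay.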